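The source may report more compounds than this note shows. Statements on the series, on what has been measured and on what is new or still open speak of the compounds shown alone.

Measured compounds:
compound 1, `CC(C)c1ccc(-c2nc(SCc3cn(CC(=O)NC(=O)Nc4ccccn4)nn3)nc(Nc3ccc(Cl)cc3)c2C#N)cc1`: > 64000 nM
compound 2, `CC(C)c1ccc(-c2nc(SCc3cn(CC(=O)NC(=O)Nc4ccccn4)nn3)nc(Nc3cccc([N+](=O)[O-])c3)c2C#N)cc1`: > 64000 nM
compound 3, `CC(C)c1ccc(-c2nc(SCc3cn(CC(=O)NC(=O)Nc4ccccn4)nn3)nc(Nc3ccccc3)c2C#N)cc1`: 15800 nM

In a functional assay on MGC-803 cells (Homo sapiens) for inhibition, read by MTT assay, with a stated time of 72 h (a higher number here means a weaker inhibitor, a lower number a stronger inhibitor), compound 1 gives > 64000 nM, which is a limit of the assay and not a number. Compound 2 likewise gives > 64000 nM, also a limit. Within the data shown here, compound 3 gives 15800 nM, the only number among the three. Compound 1 thus stands at the limit of > 64000 nM in this assay, at which 2 of the 3 values shown sit, together with compound 2, and only compound 3 lies below it.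

Compound 4, `Cc1ccc(Nc2nc(SCc3cn(CC(=O)NC(=O)Nc4ccccn4)nn3)nc(-c3ccc(C(C)C)cc3)c2C#N)cc1`, differs from compound 1 by methyl in place of chloro on an aromatic carbon. Among the measured compounds shown here, two measured steps bear on this position: an at least 4.0-fold lower number from compound 1 to compound 3 (0.60 log units; beyond the scatter) and an at least 4.0-fold lower number from compound 2 to compound 3 (0.60 log units; beyond the scatter), both showing that removing the substituent from that aromatic ring gives a lower number. The step that the two limits leave unreadable from compound 1 to compound 2 cannot be read, since both values are limits. For the measured compounds named here, no measured step tests methyl itself, so its size is a guess between the substituted and unsubstituted cases.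

The estimated step is an at least 1.6-fold lower number from compound 1 to compound 4 (0.20 log units; that floor lies within the scatter). Compound 4 is therefore expected near 40000 nM, within 15000 nM to 100000 nM.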

Compound 4, half-maximal inhibitory concentration: 3360 nM
Compound 4: the middle estimate sits 12-fold (1.08 log units) above what was measured, outside the stated range (below it).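

In this assay, among these compounds, a group on this ring is not always a penalty: methyl in place of hydrogen gives a 4.7-fold lower number from compound 3 to compound 4 (0.67 log units; beyond the scatter), whereas the earlier compounds showed only substituted rings doing worse than the bare one. What matters is which group is present, since methyl in place of chloro, a swap of one heavy atom for another, gives an at least 19-fold lower number from compound 1 to compound 4 (1.27 log units; beyond the scatter), and 4-methylphenyl in place of 3-nitrophenyl gives an at least 19-fold lower number from compound 2 to compound 4 (1.27 log units; beyond the scatter), although that second change also moves the substituent. Those two steps are only floors, because compound 1 and compound 2 each stand at a limit of the assay, not at a number: the limit of > 64000 nM in this assay, at which 2 of the 4 values shown sit.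

On these data alone, whether the benefit is special to methyl remains open, as an ethyl group, a methoxy group or an amine at this place would show. Also open, as far as these compounds go, is how methyl would behave elsewhere on the ring.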